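Chain length at the amide in the chloro series

The compounds below may be only part of what the source reports. "The series", "measured", "known", "first", "only" and "open" are said of these compounds alone.

Measured so far:
Compound 1, `Cc1ccc(-n2ncc(=O)[nH]c2=O)cc1C(=O)NCC1(O)CCCCCC1`, in a functional assay on cells for antagonist activity at P2X purinoceptor 7 (Homo sapiens), read by ELISA (a lower number here means a stronger inhibitor, a higher number a weaker inhibitor), gives 700 nM.
Compound 2, `CCCOCCNC(=O)c1cc(-n2ncc(=O)[nH]c2=O)ccc1Cl`, in this assay gives > 5000 nM, which is a limit of the assay and not a number.
Compound 3, `CCCCCCNC(=O)c1cc(-n2ncc(=O)[nH]c2=O)ccc1Cl`, in this assay gives 3600 nM.

Of the two numbers shown, compound 3 stands highest; compound 1 sits beyond the scatter below it. Among the measured compounds shown here, the one measured step on the chain is an at least 1.3-fold lower number from compound 2 to compound 3 (0.14 log units; that floor lies within the scatter), and its floor rests on (the limit of > 5000 nM in this assay, at which 1 of the 3 values shown sits).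

Compound 4 is `CCCCCNC(=O)c1cc(-n2ncc(=O)[nH]c2=O)ccc1Cl`. It differs from compound 3 by hydrogen in place of methyl on a saturated chain carbon, five bonds along the chain from an amide-type nitrogen. For the measured compounds named here, no measured step touches this kind of change: the step from compound 2 to compound 3 swaps a propoxy for a butyl close to the amide-type nitrogen, whereas here a single methyl is dropped from the far end of the chain. With no bearing evidence, the expected step is a 1.2-fold higher number from compound 3 to compound 4 (0.07 log units; within the scatter), that is, nothing beyond the scatter, with a modest lean toward a higher number.

For compound 4 the estimate in this assay is 4200 nM, in the range 1600 nM to 11000 nM.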

Compound 4, half-maximal inhibitory concentration: 2800 nM
Compound 4: the middle estimate sits 1.5-fold (0.18 log units) above what was measured; low and high end bracket the measured number.
By their numbers in this assay, from the lowest: compound 1; then compounds 4 and 3 (each within the scatter of the next). At a limit, above all of these: compound 2.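

In this assay replacing the far methyl with hydrogen gives a 1.3-fold lower number from compound 3 to compound 4 (0.11 log units; within the scatter) and so leaves the two chain compounds inseparable. Among the compounds shown here, this is the first reading at this position, since the earlier step changed the chain only two bonds along from the amide-type nitrogen. Compound 2 stands at a limit of the assay and not a number, so the step of propyl in place of propoxy, an at least 1.7-fold lower number from compound 2 to compound 4 (0.25 log units; that floor lies within the scatter), gives only a floor: the limit of > 5000 nM in this assay, at which 1 of the 4 values shown sits.

On these data alone, whether a further shortened chain, a branched chain or an amine at the chain end would move the number beyond the scatter stays open. Compound 1, at 700 nM, differs from the chloro compounds in more than one place, so its number cannot be assigned to its amide side chain alone.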